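This account rests on a few compounds, and the source may have more. Where it says the series, first, only, none or still open, it means among the compounds named here.

In a functional assay on MGC-803 cells (Homo sapiens) for antiproliferative activity, read by MTT assay, with a stated time of 48 h (on this read-out higher numbers stand for weaker inhibition and lower numbers for stronger inhibition), compound 2 (`CCCCCCCCCn1cc(COC[C@@H]2OC[C@H](N)[C@@H]2O)nn1`) gives 13800 nM, the middle of three numbers, although compound 3 (`CCCCCCCCCCCCCCn1cc(COC[C@@H]2OC[C@H](N)[C@@H]2O)nn1`) at 8210 nM lies within the scatter of it. Compound 1 (`CCCCCCCCn1cc(COC[C@@H]2OC[C@H](N)[C@@H]2O)nn1`) stands apart at 70400 nM. The next compound is compound 4 (`CCCCCCCCCCCCCCCCn1cc(COC[C@@H]2OC[C@H](N)[C@@H]2O)nn1`). The change from compound 2 is heptyl in place of hydrogen on a saturated chain carbon, nine bonds along the chain from an aromatic nitrogen.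

Within the data shown here, the closest precedent is the pentyl change at the same place, a 1.7-fold lower number from compound 2 to compound 3 (0.23 log units; within the scatter), which stays within the scatter. The steps starting from compound 1, a 5.1-fold lower number from compound 1 to compound 2 (0.71 log units; beyond the scatter) and an 8.6-fold lower number from compound 1 to compound 3 (0.93 log units; beyond the scatter), are beyond the scatter, but they act at a different chain carbon and bear less directly. Among the measured compounds shown here, no measured compound carries a chain as long as that of compound 4, so the range is kept wide. In this assay, no step beyond the scatter is expected, and any shift would most likely be towards a lower number. The expected change is a 1.7-fold lower number from compound 2 to compound 4 (0.24 log units; within the scatter). Compound 4 is estimated at 8000 nM, with an expected range of 2500 nM to 25000 nM.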

Compound 4, half-maximal inhibitory concentration: 27900 nM
The estimate for compound 4 lay 3.5-fold (0.54 log units) below the measured number; measured number above the stated range.
By their numbers in this assay, from the lowest: compounds 3 and 2 (each within the scatter of the next); then compound 4; then compound 1.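

In this assay lengthening the chain at this position no longer lowers the number: heptyl in place of hydrogen gives a 2.0-fold higher number from compound 2 to compound 4 (0.31 log units; beyond the scatter) and ethyl in place of hydrogen gives a 3.4-fold higher number from compound 3 to compound 4 (0.53 log units; beyond the scatter) so compound 4 lies above both compound 2 and compound 3, which stay within the scatter of each other. The gain over the shortest chain is only partly lost, as octyl in place of hydrogen still gives a 2.5-fold lower number from compound 1 to compound 4 (0.40 log units; beyond the scatter) even though compound 4 carries the longest chain of the series. The response to chain length at this position is therefore not one-directional across these four compounds, and no measurement on hand bears on the reason for the upturn.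

As far as these compounds go, whether a longer chain raises the number further remains open. So does the effect of an amine or a carboxylic acid in place of the chain on the shared core.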